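Trimming the amine chain of compound 1 by one carbon

This account rests on a few compounds, and the source may have more. Where it says the series, first, only, none or still open, it means among the compounds named here.

Compound 1 `CCCN(C[C@H]1Cc2c(cccc2N2CCNCC2)CN1)[C@H]1CCCc2cccnc21` was tested in an ADME assay on microsomes from liver (Mus musculus) for metabolic stability, read by LC-MS, with a stated time of 10 min (on this read-out lower numbers stand for a less stable compound and higher numbers for a more stable compound), and gave 87.4%. Of the three measured compounds it stands highest: compound 2 `C[C@@H]1CN(c2cccc3c2C[C@H](CN(C)[C@H]2CCCc4cccnc42)NC3)C[C@H](C)N1C` gave 39.6% and compound 3 `CN(C[C@H]1Cc2c(cccc2N2CCN(c3ncccn3)CC2)CN1)[C@H]1CCCc2cccnc21` gave 35.1%, both gaps from compound 1 falling beyond the usual scatter, while the two lower values lie within the scatter of one another. No two of these three compounds differ in a single place, so none of the gaps can be tied to one structural change.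

Compound 4 `CCN(C[C@H]1Cc2c(cccc2N2CCNCC2)CN1)[C@H]1CCCc2cccnc21` is the closest relative of compound 1 so far. The difference is small: hydrogen in place of methyl on a saturated chain carbon, two bonds along the chain from an amine nitrogen. Among the measured compounds shown here, no measured pair shows what this kind of change does in this assay, so the expectation rests on the shared core and on the high value of compound 1 in this assay, 87.4%. Compound 4 is therefore expected to stay near compound 1, with a step of a number 4.4 percentage points lower from compound 1 to compound 4 (within the scatter) that is not expected to reach beyond the scatter. The estimate for compound 4 in this assay is 83%, with a range from 65% to 96%.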

Compound 4, percent of the compound remaining: 53.8%
Beside the measured number, compound 4's estimate is 29.2 percentage points above it; the whole stated range lies above it.
By their numbers in this assay, from the lowest: compounds 3 and 2 (each within the scatter of the next); then compound 4; then compound 1.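

Among the compounds shown here, the pair from compound 1 to compound 4 gives the first reading of a single change in this assay: propyl gives way to ethyl, and the step is a number 33.6 percentage points lower from compound 1 to compound 4 (beyond the scatter). This chain position is therefore not a silent one, since one carbon fewer, with the shared core untouched, carries the number well beyond the scatter. No measurement at hand accounts for the size of this step.

The compounds shown leave open whether a longer chain such as butyl, or a branched group such as isopropyl, would hold the number at the level of compound 1 or take it further. A single step also cannot tell whether the same change would act alike on the other side of the shared core, where the substituents vary.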